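Swapping a Sulfone for a Sulfonamide on the Aryl Tail

A few compounds are considered here, and "the series" means these few. Any claim that something is new, unique, unknown or untested is made for them only; others in the source may bear on it.

Measured compounds:
- compound 1, `CC(C)c1noc(N2CCN(C(=O)[C@@H]3CCCN(S(=O)(=O)c4ccc(S(=O)(=O)C(C)C)cc4)C3)CC2)n1`: 70 nM
- compound 2, `CCOC(=O)[C@@H]1CCC[C@H](S(=O)(=O)c2ccc(S(=O)(=O)N(CC)CC)cc2)C1`: 21500 nM
- compound 3, `CCN(CC)S(=O)(=O)c1ccc(S(=O)(=O)N2CCC[C@@H](C(=O)NC3CN(C(=O)NC(C)(C)C)C3)C2)cc1`: 3400 nM

In a functional assay on MIA PaCa-2 cells (Homo sapiens) for inhibition, read by MTT assay, with a stated time of 7 days (on this read-out lower numbers stand for stronger inhibition and higher numbers for weaker inhibition), compound 1 gives 70 nM, the lowest of the three numbers and therefore the strongest inhibition of the set. Compound 3 comes nearest to it, yet its number lies beyond the usual scatter, and compound 2 lies further still. Both of those two differ from compound 1 in more than one place, so none of these gaps can be tied to a single structural change.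

Compound 4, `CC(C)c1noc(N2CCN(C(=O)[C@@H]3CCCN(S(=O)(=O)c4ccc(S(=O)(=O)NC5CCC5)cc4)C3)CC2)n1`, is the next step. It differs from compound 1 in one place only:

cyclobutylamino in place of isopropyl on a sulfonyl sulfur

Going by the values given here, no measured pair shows this change on its own, so the step must be estimated from the shape of the series. Compound 3, which also carries a sulfamoyl group on the aromatic ring and gives 3400 nM, is weaker than compound 1, but its other differences prevent that gap from being read as the effect of the sulfamoyl group alone. For compound 4 a small loss is expected, a step of a 2.1-fold higher number from compound 1 to compound 4 (0.33 log units; beyond the scatter) in this assay. Compound 4 is therefore estimated at 150 nM, with a likely range from 40 nM to 600 nM.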

Compound 4, half-maximal inhibitory concentration: 600 nM
Beside the measured number, compound 4's estimate is 4.0-fold (0.60 log units) below it, within the range that was stated.
By their numbers in this assay, from the lowest: compound 1; then compound 4; then compound 3; then compound 2.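

Going by these compounds alone, for the first time, one change can be read on its own: in this assay cyclobutylamino in place of isopropyl on a sulfonyl sulfur gives an 8.6-fold higher number from compound 1 to compound 4 (0.93 log units; beyond the scatter) and so weaker inhibition. Within the data shown here, the swap brings in a nitrogen with one hydrogen-bond donor and a four-membered ring of carbon while the rest of the molecule stays the same, so the loss belongs to this one place, something the earlier compounds, which all differ in more than one place, could not show. Which part of the new group accounts for the loss cannot be told, and no measurement here speaks to its cause.

From the compounds shown here alone, the swap alters the nitrogen and the ring together, so it remains open how isopropylamino, which keeps the nitrogen but not the ring, or cyclobutyl, which keeps the ring but not the nitrogen, would compare on the same sulfonyl sulfur. Also open, going by these compounds, is whether dimethylamino, which has no hydrogen on its nitrogen, would stay nearer to compound 1 or to compound 4.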